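Compound 4 Weighed Against Compound 2 in the Agonist Assay

The compounds below may be only part of what the source reports. "The series", "measured", "known", "first", "only" and "open" are said of these compounds alone.

Of the compounds shown here, three have been measured in a functional assay on HEK293 cells for agonist activity at D(4) dopamine receptor (Homo sapiens), read by FLIPR; on this read-out higher numbers stand for larger maximal responses and lower numbers for smaller maximal responses. Compound 2 `O=C(CN1CCC(c2cccc[n+]2[O-])CC1)NC1CCCCC1` gives 58%, the second highest of the three numbers. Compound 1 `Cc1cccc(NC(=O)CN2CCC(c3nccs3)CC2)c1` gives 62% in this assay, and compound 3 `CCOc1cccc(C(=O)NCN2CCC(c3cccc[n+]3[O-])CC2)c1` gives 54%; both lie within the scatter of the value for compound 2, so the three cannot be told apart. Compound 4 `O=C(CN1CCC(c2cccc[n+]2[O-])CC1)Nc1cc(Cl)cc(Cl)c1` awaits measurement. It differs from compound 2 in one place: 3,5-dichlorophenyl in place of cyclohexyl on an amide-type nitrogen. The cyclohexyl leaves and 3,5-dichlorophenyl enters on the amide-type nitrogen. Among the measured compounds shown here, no measured pair isolates such a change, so no step beyond the scatter is expected in either direction. Compound 4 is expected to give 60%, between 45% and 75%. The expected step is a number 2 percentage points higher from compound 2 to compound 4 (within the scatter), within the scatter.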

Compound 4, largest response reached (reported as efficacy), in percent of the reference or control that the assay uses: 68%
Estimate against measurement, compound 4: 8 percentage points below; measured number inside the range.
By their numbers in this assay, from the lowest: compounds 3, 2, 1 and 4 (each within the scatter of the next, the first and the last beyond it).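

In this assay, among the compounds shown here, the pair gives the first reading of a change on this amide-type nitrogen: 3,5-dichlorophenyl in place of cyclohexyl gives a number 10 percentage points higher from compound 2 to compound 4 (within the scatter). Swapping the non-aromatic carbon ring for an aromatic one bearing two chlorines therefore leaves compound 4 indistinguishable from compound 2 on this read-out. No available evidence accounts for this result.

The compounds shown leave open how unsubstituted phenyl or 3-chlorophenyl would compare on this nitrogen. They also leave open whether a carboxylic acid or an amine carried on the ring would keep the response.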